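Urea series: aryl amine swap from compound 2 to compound 3

The source may report more compounds than this note shows. Statements on the series, on what has been measured and on what is new or still open speak of the compounds shown alone.

Measured so far:
compound 1 `Cc1ccc(Nc2cc(NC(=O)Nc3c(Cl)cccc3Cl)ncn2)cc1F` — 92%
compound 2 `CCc1ccc(Nc2cc(NC(=O)Nc3cc(OC)cc(OC)c3)ncn2)cc1` — 78%

Both readings come from a functional assay on PC-9 cells (Homo sapiens) for inhibition, read by MTT assay, with a stated time of 48 h, tested at 10 uM; a higher number here means more inhibition at the concentration tested (going by the name of the read-out), a lower number less inhibition. Compound 2 stands lowest of the two numbers; its nearest neighbour is compound 1, which lies higher by a gap beyond the scatter. Among the measured compounds shown here, no single-point step between the two measured compounds can be drawn, since they differ in more than one place.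

Compound 3 `COc1cc(NC(=O)Nc2cc(Nc3ccc(F)c(Cl)c3)ncn2)cc(OC)c1` is the next entry for this assay. Relative to compound 2 the change is 3-chloro-4-fluorophenyl in place of 4-ethylphenyl on a nitrogen on an aromatic ring; the urea part is kept unchanged.

Compound 1, which also carries a halogen-bearing aryl on that nitrogen, gives 92%, so a small rise is plausible, but the expected step of a number 7 percentage points higher from compound 2 to compound 3 (within the scatter) is not beyond the scatter. Compound 3 is therefore estimated at 85%, with a range from 70% to 96%.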

Compound 3, a percentage reported as inhibition, at one concentration (the size of the read-out at that concentration, not a potency): 77.5%
Estimate against measurement, compound 3: 7.5 percentage points above, within the range that was stated.
By their numbers in this assay, from the lowest: compounds 3 and 2 (each within the scatter of the next); then compound 1.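

In this assay, 3-chloro-4-fluorophenyl in place of 4-ethylphenyl on a nitrogen on an aromatic ring gives a number 0.5 percentage points lower from compound 2 to compound 3 (within the scatter), with the urea part unchanged. Among the compounds shown here, this is the first single-place reading at this position: at the one concentration tested, the two aryl groups, each of 8 heavy atoms, are not told apart. Nothing available bears on why these two groups read alike.

As far as these compounds go, whether the same swap reads alike with another urea part stays open, as compound 1 differs from compound 2 and compound 3 in more than one place. Also open, from the compounds shown here alone, is how this position reads with a longer alkyl chain in place of the ethyl of 4-ethylphenyl, or with a carboxylic acid on the aryl ring.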